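Replacing the Ester Side Chain of Compound 3

The source may report more compounds than this note shows. Statements on the series, on what has been measured and on what is new or still open speak of the compounds shown alone.

Compound 1, `CC1=NC(C)=C(C(=O)O)C(c2ccccc2)/C1=C(\O)OC/C=C/c1ccccc1`: in a functional assay on thoracic aorta for inhibition of Voltage-gated L-type calcium channel (Rattus norvegicus) (on this read-out lower numbers stand for stronger inhibition and higher numbers for weaker inhibition), compound 1 gives 9 nM
Compound 2, `CC1=NC(C)=C(C(=O)O)C(c2cccc(C(=O)O)c2)/C1=C(\O)OC/C=C/c1ccccc1`: for compound 2 this assay reports only a limit, > 10000 nM
Compound 3, `CC1=NC(C)=C(C(=O)O)C(c2cccc(Cl)c2)/C1=C(\O)OC/C=C/c1ccccc1`: compound 3 gives 20 nM

The three measured compounds share one core and one ester side chain and differ only on the aromatic ring carried by the core. Among the measured compounds shown here, compound 3 holds the higher of the two numbers; the only other number belongs to compound 1, and the step of a 2.2-fold higher number from compound 1 to compound 3 (0.35 log units; beyond the scatter) is modest. The other two steps, an at least 1100-fold higher number from compound 1 to compound 2 (3.04 log units; beyond the scatter) and an at least 500-fold lower number from compound 2 to compound 3 (2.69 log units; beyond the scatter), are large, but each is read against the limit of > 10000 nM in this assay, at which 1 of the 3 values shown sits, rather than against a number.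

Compound 4, `CC1=NC(C)=C(C(=O)O)C(c2cccc(Cl)c2)/C1=C(\O)OCC(=O)Nc1ccccc1`, differs from compound 3 by phenylcarbamoyl in place of 2-phenylethenyl on a saturated chain carbon bound to an oxygen on an unsaturated carbon. Seen one bond further out, 3-phenylprop-2-en-1-yl gives way to (phenylcarbamoyl)methyl. For the measured compounds named here, no measured step touches this part of the molecule: all three concern the aromatic ring, not the ester side chain. The measured record therefore gives no direction for this change, and no step beyond the scatter is expected, though the range must stay wide. Compound 4 is estimated at 30 nM, between 5 nM and 200 nM. The expected step is a 1.5-fold higher number from compound 3 to compound 4 (0.18 log units; within the scatter).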

Compound 4, half-maximal inhibitory concentration: 50 nM
Beside the measured number, compound 4's estimate is 1.7-fold (0.22 log units) below it, within the range that was stated.
By their numbers in this assay, from the lowest: compound 1; then compound 3; then compound 4. At a limit, above all of these: compound 2.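

Among the compounds shown here, this is the first measured change to the ester side chain, since the earlier steps all concerned the aromatic ring on the core. In this assay, the step is a 2.5-fold higher number from compound 3 to compound 4 (0.40 log units; beyond the scatter), which is beyond the scatter but modest, so this position accepts phenylcarbamoyl in place of 2-phenylethenyl at only a small cost in inhibition, even though the new group adds a hydrogen-bond donor and a hydrogen-bond acceptor while keeping the aromatic ring and a double bond outside it. Nothing shown here accounts for why the number rises on this change.

A single step cannot separate the contributions of the amide and the loss of the carbon-carbon double bond, and it cannot show whether the same swap would cost as little on compound 1, which has no chloro group on its aromatic ring. Going by these compounds, it also remains open how much of the side chain is needed for inhibition, for example whether a simple methyl ester or a dimethylamino group in place of the phenyl ring of the side chain would keep compound 4's inhibition.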